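Lengthening the alkylamino chain: from propyl to butyl

The compounds below may be only part of what the source reports. "The series", "measured", "known", "first", "only" and "open" are said of these compounds alone.

The series shares one core, varied only at the amino substituent on the aromatic ring. Compound 1 `CNc1ccc(C(=O)N2CCCCc3ccccc32)c(Cl)c1` carries a methylamino group and gives 35 nM in an assay on HeLa cells for binding affinity to Vasopressin V2 receptor (Homo sapiens); a higher number here means a weaker inhibitor, a lower number a stronger inhibitor. Compound 2 `CCN(CC)c1ccc(C(=O)N2CCCCc3ccccc32)c(Cl)c1` carries a diethylamino group and gives 19 nM in this assay. Compound 3 `CCCNc1ccc(C(=O)N2CCCCc3ccccc32)c(Cl)c1` carries a propylamino group and gives 18 nM in this assay; this is the lowest of the three numbers, yet it sits within the scatter of both others, so no order among them can be claimed. The step of a 1.8-fold lower number from compound 1 to compound 2 (0.27 log units; within the scatter) and the step of a 1.9-fold lower number from compound 1 to compound 3 (0.29 log units; within the scatter) both lie within the scatter, as does a 1.1-fold lower number from compound 2 to compound 3 (0.02 log units; within the scatter).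

Compound 4 `CCCCNc1ccc(C(=O)N2CCCCc3ccccc32)c(Cl)c1` extends the chain by one carbon: methyl in place of hydrogen on a saturated chain carbon, three bonds along the chain from a nitrogen on an aromatic ring. The most comparable measured step is a 1.9-fold lower number from compound 1 to compound 3 (0.29 log units; within the scatter), a chain extension by two carbons that stayed within the scatter. A single added carbon on an already longer chain is therefore expected to move this assay little, if at all, in either direction beyond the scatter. Compound 4 is estimated at 15 nM, with a range from 6 nM to 40 nM, which corresponds to an expected step of a 1.2-fold lower number from compound 3 to compound 4 (0.08 log units; within the scatter).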

Compound 4, half-maximal inhibitory concentration: 22 nM
Estimate against measurement, compound 4: 1.5-fold (0.17 log units) below; the measured number falls inside the stated range.
By their numbers in this assay, from the lowest: compounds 3, 2, 4 and 1 (each within the scatter of the next).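

In this assay, going by these compounds alone, the difference of propyl to butyl gives a 1.2-fold higher number from compound 3 to compound 4 (0.09 log units; within the scatter), so this position takes the added methyl with no step that can be told from the scatter. The butylamino group also stays within the scatter of the other amino groups, with a 1.2-fold higher number from compound 2 to compound 4 (0.06 log units; within the scatter) against diethylamino and a 1.6-fold lower number from compound 1 to compound 4 (0.20 log units; within the scatter) against methylamino, which means the four compounds now shown, taken pair by pair, cannot be put in any order by these numbers. No independent evidence bears on this result, so the numbers give no account of it.

The compounds shown leave open whether these numbers stay within the scatter of one another with a longer chain such as pentyl or hexyl, with a branched chain such as isopropyl, or with a chain that ends in a hydroxyl group or an amine. They also leave open what a plain amino group without any alkyl chain, or a dipropylamino group with two propyl chains on the nitrogen, would give in this series.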